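From bromo to cyano: notes on compound 4

A few compounds are considered here, and "the series" means these few. Any claim that something is new, unique, unknown or untested is made for them only; others in the source may bear on it.

Measured in a functional assay on BT-474 cells (Homo sapiens) for inhibition, read by MTT assay, with a stated time of 5 days; a lower number here means a stronger inhibitor, a higher number a weaker inhibitor:
- compound 1 `Cc1cc(Nc2nc(NCc3ccc(F)cc3)nc3[nH]ncc23)n[nH]1`: 8750 nM
- compound 2 `Cc1cc(Nc2nc(NCc3ccc(Cl)cc3)nc3[nH]ncc23)n[nH]1`: 11700 nM
- compound 3 `Cc1cc(Nc2nc(NCc3ccc(Br)cc3)nc3[nH]ncc23)n[nH]1`: 4110 nM

Compound 3 has the lowest number of the three in this assay. The next structure, compound 4 `Cc1cc(Nc2nc(NCc3ccc(C#N)cc3)nc3[nH]ncc23)n[nH]1`, carries cyano in place of bromo on an aromatic carbon. Three measured steps at this place bear on it: a 1.3-fold higher number from compound 1 to compound 2 (0.13 log units; within the scatter), a 2.1-fold lower number from compound 1 to compound 3 (0.33 log units; beyond the scatter) and a 2.8-fold lower number from compound 2 to compound 3 (0.45 log units; beyond the scatter). All are exchanges among fluoro, chloro and bromo, and none involves cyano, so they suggest a size but not firmly a direction. A modest step towards a higher number is expected, since compound 3 gives the lowest value, 4110 nM. The expected step is a 1.8-fold higher number from compound 3 to compound 4 (0.26 log units; within the scatter). For compound 4 the estimated value is 7500 nM, with an expected range of 2500 nM to 20000 nM.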

Compound 4, half-maximal inhibitory concentration: 12100 nM
Beside the measured number, compound 4's estimate is 1.6-fold (0.21 log units) below it; measured number inside the range.
By their numbers in this assay, from the lowest: compound 3; then compounds 1, 2 and 4 (each within the scatter of the next).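

In this assay, for the compounds shown here, cyano is the only group at this position that is not a halogen, and the exchange for bromo gives a 2.9-fold higher number from compound 3 to compound 4 (0.47 log units; beyond the scatter), so the low number of compound 3 does not carry over to it. Set against the other halogens, cyano gives a 1.0-fold higher number from compound 2 to compound 4 (0.01 log units; within the scatter) and a 1.4-fold higher number from compound 1 to compound 4 (0.14 log units; within the scatter). Compounds 1, 2 and 4 therefore sit together, with compound 3 alone apart from them.

Going by these compounds, whether an amine, a carboxylic acid or a methoxy group here would join those three or approach compound 3 stays open. No measurement at hand accounts for the separate position of compound 3.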